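This account rests on a few compounds, and the source may have more. Where it says the series, first, only, none or still open, it means among the compounds named here.

Working notes on the series.

Of the compounds shown here, two have been measured so far in an assay on brain with Translocator protein (Rattus norvegicus) as the target; on this read-out lower numbers stand for stronger inhibition and higher numbers for weaker inhibition. Compound 1 `CCN(CC)C(=O)c1cc(-c2ccccc2)c2ccccc2c1` gives 5 nM in this assay. Compound 2 `CCOC(=O)c1c(N(CC)Cc2ccccc2)nc2ccccc2c1-c1ccccc1` gives 540 nM in this assay, the higher of the two numbers; the gap between compound 2 and compound 1 lies beyond the scatter, so compound 2 is the weaker of the two. Among the measured compounds shown here, the two compounds share no single-point difference, so no step between measured compounds can be read from them.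

Compound 3 `CCOC(=O)c1c(Cl)nc2ccccc2c1-c1ccccc1` is not yet measured in this assay. Against compound 2 the change is chloro in place of benzyl(ethyl)amino on an aromatic carbon. For the measured compounds named here, nothing in the measured pair shows what this exchange does; the only anchor is the value of compound 2, which already sits at the weak end of what has been seen.

The step from compound 2 to compound 3 is expected to be a 9.3-fold higher number from compound 2 to compound 3 (0.97 log units; beyond the scatter), toward weaker inhibition, beyond the scatter. For compound 3 the expected value in this assay is 5000 nM, with a range from 800 nM to 30000 nM.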

Compound 3, half-maximal inhibitory concentration: 3700 nM
For compound 3 the middle estimate is 1.4-fold (0.13 log units) above the measured one, within the range that was stated.
By their numbers in this assay, from the lowest: compound 1; then compound 2; then compound 3.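

In this assay, among the compounds shown here, replacing benzyl(ethyl)amino with chloro on the aromatic carbon next to the ring nitrogen gives a 6.9-fold higher number from compound 2 to compound 3 (0.84 log units; beyond the scatter), the first step that can be read. This shows that the position responds to what it carries, and that of these two groups the benzyl(ethyl)amino of 10 heavy atoms goes with the lower number, with the ethoxycarbonyl and phenyl groups unchanged. No measured property accompanies this step, so the data offer no account of why the number moves.

The change removes a whole group at once, so the compounds shown cannot separate the contributions of its nitrogen, its ethyl chain and its benzyl ring. Going by these compounds, it remains open whether a simple dimethylamino group, or a benzylamino group without the ethyl chain, would give a number closer to that of compound 2 at 540 nM or closer to that of compound 3 at 3700 nM.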